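Furan-2-yl for phenyl: an estimate for compound 4

This account rests on a few compounds, and the source may have more. Where it says the series, first, only, none or still open, it means among the compounds named here.

Among the measured compounds shown here, compound 1 `CC1=CC[C@H](C(C)(C)NC(=S)N/N=C/c2ccccc2)CC1` is the one member of this set with a numerical result: in a functional assay on PC-3 cells (Homo sapiens) for inhibition, read by sulforhodamine B assay, with a stated time of 48 h (a lower number here means a stronger inhibitor of growth, a higher number a weaker inhibitor of growth), compound 1 gives 1300 nM. Compound 2 `COc1ccc(/C=N/NC(=S)NC(C)(C)[C@H]2CC=C(C)CC2)cc1` reaches only a limit of the assay, < 40 nM. Compound 3 `CC1=CC[C@H](C(C)(C)NC(=S)N/N=C/c2ccccc2O)CC1` likewise sits at a limit, < 40 nM. Compound 4 `CC1=CC[C@H](C(C)(C)NC(=S)N/N=C/c2ccco2)CC1` differs from compound 1 by furan-2-yl in place of phenyl on a carbon with a double bond to nitrogen. The measured steps decorate the phenyl ring rather than replace it: an at least 32-fold lower number from compound 1 to compound 2 (1.51 log units; beyond the scatter) and an at least 32-fold lower number from compound 1 to compound 3 (1.51 log units; beyond the scatter), both large, while a step that the two limits leave unreadable from compound 2 to compound 3. None of these covers exchange of the ring itself, so for compound 4 no step beyond the scatter is expected in either direction, though with wide uncertainty. Compound 4 is therefore estimated at 900 nM, within 200 nM to 4000 nM, which means a 1.4-fold lower number from compound 1 to compound 4 (0.16 log units; within the scatter).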

Compound 4, concentration for 50% growth inhibition: 13500 nM
Compound 4: the middle estimate sits 15-fold (1.18 log units) below what was measured, outside the stated range (above it).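

Exchanging the ring itself at this place, on a carbon with a double bond to nitrogen, costs growth inhibition: furan-2-yl gives a 10-fold higher number from compound 1 to compound 4 (1.02 log units; beyond the scatter), whereas the added groups on phenyl lowered the number. Against the substituted phenyl rings the gap is wider, an at least 330-fold higher number from compound 3 to compound 4 (2.52 log units; beyond the scatter) and an at least 330-fold higher number from compound 2 to compound 4 (2.52 log units; beyond the scatter). Compound 2 and compound 3 each sit at a limit of the assay, so these two steps are bounds: the limit of < 40 nM in this assay, at which 2 of the 4 values shown sit.

From the compounds shown here alone, whether a methoxy or hydroxy group on furan-2-yl would recover the loss stays open. So does the effect of an amine or a carboxylic acid on the phenyl ring.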